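A few compounds are considered here, and "the series" means these few. Any claim that something is new, unique, unknown or untested is made for them only; others in the source may bear on it.

Values measured in an ADME assay on microsomes from liver (Mus musculus) for metabolic stability, read by mass spectrometry, with a stated time of 40 min, tested at 1 uM; on this read-out lower numbers stand for a less stable compound and higher numbers for a more stable compound:
- compound 1 `COc1cc(N2CCC(CC(=O)N3CCN(C)CC3)CC2)ccc1Nc1nc(NC2CCCCC2)c2nc[nH]c2n1`: 43%
- compound 2 `COc1cc(N2CCC(CC(=O)N3CCC(N(C)C)C3)CC2)ccc1Nc1nc(NC2CCCCC2)c2nc[nH]c2n1`: 48%
- compound 3 `COc1cc(N2CCC(CC(=O)N3CCCC3)CC2)ccc1Nc1nc(NC2CCCCC2)c2nc[nH]c2n1`: 59%

Compound 3 has the highest number of the three, and its steps to the other two lie beyond the scatter. The next compound, compound 4 `COc1cc(N2CCC(C(=O)N3CC(O)C3)CC2)ccc1Nc1nc(NC2CCCCC2)c2nc[nH]c2n1`, differs from it on a saturated ring carbon: (3-hydroxyazetidin-1-yl)carbonyl stands in place of ((pyrrolidin-1-yl)carbonyl)methyl ((3-hydroxyazetidin-1-yl)carbonyl in place of ((pyrrolidin-1-yl)carbonyl)methyl on a saturated ring carbon).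

Within the data shown here, three measured steps bear on this change: a number 16 percentage points higher from compound 1 to compound 3 (beyond the scatter), a number 11 percentage points higher from compound 2 to compound 3 (beyond the scatter) and a number 5 percentage points higher from compound 1 to compound 2 (within the scatter). The first two are modest, and the third stays within the scatter. All three change only the ring on the carbonyl carbon. None tests a hydroxy group, a four-membered ring or the loss of the carbon link, so they suggest a size but no direction.

In this assay no step beyond the scatter is therefore expected, though a step the size of a number 11 percentage points higher from compound 2 to compound 3 (beyond the scatter) in either direction remains possible. The expected step is a number 1 percentage points higher from compound 3 to compound 4 (within the scatter). For compound 4 the estimate is 60%, with an expected range from 42% to 78%.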

Compound 4, percent of the compound remaining: 65%
Compound 4: middle estimate off by 5 percentage points, on the low side, and the stated range covers the measured number.
By their numbers in this assay, from the lowest: compounds 1 and 2 (each within the scatter of the next); then compounds 3 and 4 (each within the scatter of the next).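

In this assay the result is a number 6 percentage points higher from compound 3 to compound 4 (within the scatter) when (3-hydroxyazetidin-1-yl)carbonyl replaces ((pyrrolidin-1-yl)carbonyl)methyl, so on this read-out the saturated ring carbon accepts the loss of the carbon link, a four-membered ring and a hydroxy group all at once without a measurable change. Measured against the groups that carry a further amine, the same new group gives a number 17 percentage points higher from compound 2 to compound 4 (beyond the scatter) and a number 22 percentage points higher from compound 1 to compound 4 (beyond the scatter) on the same carbon, so the change from those two compounds is larger than the scatter, though still modest. Nothing measured here explains why these numbers come out as they do.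

All three features change together in compound 4, so the share of each cannot be separated. Going by these compounds, how a plain azetidin-1-yl group without the hydroxy, or a longer chain between the ring carbon and the carbonyl, would behave at this place stays open.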